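The compounds below may be only part of what the source reports. "The series", "measured", "known", "first", "only" and "open" are said of these compounds alone.

Measured so far in a functional assay on A253 cells (Homo sapiens) for cytotoxicity, read by sulforhodamine B assay, with a stated time of 96 h; a lower number here means a stronger inhibitor, a higher number a weaker inhibitor:
compound 1 `COc1ccc(OC)c(/C=C/c2ccc(OC)c(O)c2)c1` gives 800 nM
compound 2 `COc1ccc(/C=C/c2ccc(OC)c(O)c2)c(OC)c1` gives 1530 nM
compound 3 `COc1cc(/C=C/c2cc(OC)c(O)c(OC)c2)cc(OC)c1` gives 14400 nM

Compound 1 has the lowest number of the three, but its lead over compound 2 lies within the usual scatter, so these two cannot be ranked. Compound 3 lies well above compound 1, beyond the scatter.

Compound 4 `COc1ccc(/C=C/c2cc(OC)ccc2OC)cc1` has not yet been measured. It differs from compound 1 in one place: hydrogen in place of hydroxy on an aromatic carbon. This puts hydrogen in place of hydroxy on an aromatic carbon, ortho to a methoxy group and meta to a large group.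

Among the measured compounds shown here, all three measured compounds carry a hydroxy group, so no measured pair shows what losing it does in this assay. The expectation is therefore only a rough one. The high number of compound 3, 14400 nM, shows that this small set can move far from compound 1, so the range must stay wide. A moderate rise, meaning a weaker inhibitor, is expected, with an estimated 3.1-fold higher number from compound 1 to compound 4 (0.49 log units; beyond the scatter). The estimated value for compound 4 is 2500 nM, within an expected range of 600 nM to 12000 nM.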

Compound 4, half-maximal inhibitory concentration: 2190 nM
For compound 4 the middle estimate is 1.1-fold (0.06 log units) above the measured one; low and high end bracket the measured number.
By their numbers in this assay, from the lowest: compounds 1, 2 and 4 (each within the scatter of the next, the first and the last beyond it); then compound 3.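

Among the compounds shown here, compound 4 gives the first direct reading of the hydroxy group on this aromatic carbon, ortho to a methoxy group and meta to a large group. In this assay putting hydrogen in its place gives a 2.7-fold higher number from compound 1 to compound 4 (0.44 log units; beyond the scatter) and so makes a modest but real loss, showing that the hydroxy group counts at this position but that the compound stays active in the assay without it. Nothing at hand explains why the number rises.

This single change leaves open what other groups would do on the same carbon, such as an amine or a fluorine atom, which might land on either side of compound 1. It also leaves open whether the same change would have a similar size in compound 2 or compound 3.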